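The source may report more compounds than this note shows. Statements on the series, on what has been measured and on what is new or still open speak of the compounds shown alone.

Measured so far in a functional assay on HeLa cells (Homo sapiens) for inhibition; a higher number here means a weaker inhibitor, a lower number a stronger inhibitor:
Compound 1 `CCN(CC)CCNC(=O)CC(CC(=O)NC1Cc2ccccc2C1)c1ccccc1` gives > 100000 nM (a limit of the assay)
Compound 2 `CN(C(=O)CC(CC(=O)NCCN1CCCC1)c1ccccc1)C1Cc2ccccc2C1` gives > 100000 nM (a limit of the assay)

Compound 2 has no number of its own in this assay and stands only at the limit of > 100000 nM (its single reported result). Among the compounds with values here, compound 1 sits at that same limit, so the two compounds offer no measured step to work from.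

Compound 3 `CCN(CC)CCNC(=O)CC(CC(=O)N(C)C1Cc2ccccc2C1)c1ccccc1` differs from compound 2 in one place, on a saturated chain carbon, two bonds along the chain from an amide-type nitrogen, where diethylamino stands in place of pyrrolidin-1-yl: diethylamino in place of pyrrolidin-1-yl on a saturated chain carbon, two bonds along the chain from an amide-type nitrogen (the full count of the change). Diethylamino is already present in compound 1, and pyrrolidin-1-yl in compound 2, and neither compound gives a number.

With compound 1 and compound 2 both resting on (the limit of > 100000 nM in this assay, at which 2 of the 2 values shown sit), no change beyond the usual scatter is expected in this assay. The expected size of a number no higher from compound 2 to compound 3 (the limit leaves the size open) is therefore close to nothing. For compound 3 the estimated value is 100000 nM, with an expected range from 30000 nM to 300000 nM, and a further report at the limit is the likeliest outcome.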

Compound 3, half-maximal inhibitory concentration: > 100000 nM
Compound 3: only a limit was reported (the forecaster's own chance of this, stated with the estimate: 85%); the middle value sits exactly at the limit.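

In this assay compound 3 gives > 100000 nM as a limit of the assay. No step from compound 1 or compound 2 to compound 3 can be read: the limit of > 100000 nM in this assay, at which 3 of the 3 values shown sit.
The compounds shown leave open whether diethylamino in place of pyrrolidin-1-yl, or methyl in place of hydrogen on an amide-type nitrogen, changes inhibition at all.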